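This account rests on a few compounds, and the source may have more. Where it says the series, first, only, none or still open, it means among the compounds named here.

Compound 1 `COCCOc1cc2oc(=O)n(CCC(=O)O)c2cc1Cl` is the starting point of this step. In a physicochemical assay for permeability, using PAMPA (on this read-out lower numbers stand for lower permeability and higher numbers for higher permeability), compound 1 gives only a limit, < 3 nm/s, so its true number is not known. Compound 3 `CCOc1cc2oc(=O)n(CCC(=O)O)c2cc1Cl` likewise gives only a limit in this assay, < 10 nm/s. Compound 2 `Cc1ccc([C@@H](C)Oc2cc3oc(=O)n(CCC(=O)O)c3cc2Cl)nc1` gives a number in this assay, 22 nm/s. The step that the two limits leave unreadable from compound 1 to compound 3 cannot be read as a size, since the limit of < 3 nm/s in this assay, at which 1 of the 3 values shown sits, and the limit of < 10 nm/s in this assay, at which 1 of the 3 values shown sits, both stand at limits. The step of an at least 2.2-fold lower number from compound 2 to compound 3 (0.34 log units; beyond the scatter) runs downward, so the reverse replacement, an aromatic group entering on the chain carbon bound to the ring oxygen, came with a higher number. Compound 4 `C[C@@H](Oc1cc2oc(=O)n(CCC(=O)O)c2cc1Cl)c1ncco1` differs from compound 1 in that (a group of 7 heavy atoms (5 carbon, 1 nitrogen, 1 oxygen; one five-membered aromatic ring with 2 hetero atoms) in place of a group of 4 heavy atoms (3 carbon, 1 oxygen; no ring), on an oxygen on an aromatic ring). For the measured compounds named here, that change is of the same kind as the one from compound 3 to compound 2, an aromatic group entering at the ring oxygen, so a rise beyond the scatter is expected, the step of an at least 5.0-fold higher number from compound 1 to compound 4 (0.69 log units; beyond the scatter). Compound 4 is therefore estimated at 15 nm/s, within 5 nm/s to 40 nm/s.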

Compound 4, apparent permeability: < 3 nm/s
Compound 4 gave a limit, no number (the forecaster's own chance of this, stated with the estimate: 20%); middle value at least 5.0-fold (0.69 log units) away from the limit.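

In this assay, an aromatic group on the saturated chain carbon bound to an oxygen on an aromatic ring does not by itself bring a higher number: replacing 5-methylpyridin-2-yl with 1,3-oxazol-2-yl there comes with an at least 7.3-fold lower number from compound 2 to compound 4 (0.86 log units; beyond the scatter). At this position, then, the identity of the aromatic group matters, and among the four compounds only compound 2 gives a number rather than a limit. The steps from compound 1 and from compound 3 to compound 4 cannot be read, since each ends at the limit of compound 4: the limit of < 3 nm/s in this assay, at which 2 of the 4 values shown sit.

From the compounds shown here alone, how far compounds 1, 3 and 4 truly lie from one another remains open. Also open, going by these compounds, is whether a phenyl ring on the same chain carbon would side with compound 2 or compound 4.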